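The source may hold more compounds than are shown below. What is called first, only, known or untested is meant among the compounds shown, and "the series" means these compounds.

Measured so far:
- compound 1, `Cc1cn([C@@H]2O[C@H](CO[Si](C)(C)C(C)(C)C)[C@@]3(OS(=O)(=O)C=C3NCC(N)=O)[C@H]2O[Si](C)(C)C(C)(C)C)c(=O)n(C)c1=O`: 16000 nM
- compound 2, `CCOC(=O)CNC(=O)NC1=CS(=O)(=O)O[C@@]12[C@@H](CO[Si](C)(C)C(C)(C)C)O[C@@H](n1cc(C)c(=O)n(C)c1=O)[C@@H]2O[Si](C)(C)C(C)(C)C`: 16000 nM

Compound 1 was tested in a functional assay on HEL cells (Homo sapiens) for cytotoxicity, read by microscopy (on this read-out higher numbers stand for lower toxicity in this test and lower numbers for higher toxicity in this test), where compound 1 gives 16000 nM. Compound 2 is its closest measured neighbour; in this assay compound 2 gives 16000 nM, and the step of no change at the digits printed from compound 1 to compound 2 (within the scatter) shows that swapping the side chain on the amine nitrogen left the read-out where it was. Going by the values given here, compound 1 therefore stands level with compound 2, the only other measured compound.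

Compound 3, `Cc1cn([C@@H]2O[C@H](CO[Si](C)(C)C(C)(C)C)[C@@]3(OS(=O)(=O)C=C3NCCC(=O)O)[C@H]2O[Si](C)(C)C(C)(C)C)c(=O)n(C)c1=O`, has not yet been measured. It differs from compound 1 by carboxymethyl in place of carbamoyl on a saturated chain carbon bound to an amine nitrogen. Among the compounds with values here, no measured step covers exactly this exchange; the one step available, from compound 1 to compound 2, alters the same side chain on the amine nitrogen and produced no change within the scatter, which is the only guide at hand. On that basis, a step of about no change at the digits printed from compound 1 to compound 3 (within the scatter) is expected, that is, no movement beyond the scatter in this assay. Compound 3 is thus estimated to give 16000 nM in this assay, with a range from 6000 nM to 40000 nM.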

Compound 3, minimum cytotoxic concentration: 80000 nM
Beside the measured number, compound 3's estimate is 5.0-fold (0.70 log units) below it; measured number outside the range, above it.
By their numbers in this assay, from the lowest: compounds 1 and 2 (each within the scatter of the next); then compound 3.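

In this assay, the side chain on the amine nitrogen proved able to move the read-out, which the earlier pair had not shown: that exchange gave no change at the digits printed from compound 1 to compound 2 (within the scatter), whereas carboxymethyl in place of carbamoyl on a saturated chain carbon bound to an amine nitrogen gives a 5.0-fold higher number from compound 1 to compound 3 (0.70 log units; beyond the scatter). The shift also appears against the other measured neighbour, with 2-carboxyethyl in place of ((ethoxycarbonyl)methyl)carbamoyl on an amine nitrogen giving a 5.0-fold higher number from compound 2 to compound 3 (0.70 log units; beyond the scatter), so in this small set the higher number, which stands for lower toxicity in this test, belongs to the compound carrying the carboxylic acid. Nothing among the data shown explains why this side chain shifts the read-out.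

Going from carbamoylmethyl to 2-carboxyethyl changes both the end group and the chain length, so these compounds cannot separate the contribution of the carboxylic acid from that of the longer chain; a 2-carbamoylethyl group or a carboxymethyl group directly on the amine nitrogen would pull the two apart. Also open, going by these compounds, is how a different end group on the same chain, such as a 2-aminoethyl group, would read in this assay.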